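From hydroxy to nitro on the aromatic ring

A few compounds are considered here, and "the series" means these few. Any claim that something is new, unique, unknown or untested is made for them only; others in the source may bear on it.

In a functional assay on HT-29 cells (Homo sapiens) for cytotoxicity, read by sulforhodamine B assay (a lower number here means a stronger inhibitor of growth, a higher number a weaker inhibitor of growth), compound 1 `CC1=CC[C@@H]([C@@](C)(O)CCCC(C)(C)NC=S)CC1` (47900 nM) and compound 3 `CC1=CC[C@@H]([C@@](C)(O)CCCC(C)(C)NC(=S)N/N=C\c2ccc(O)cc2)CC1` (31500 nM) lie within the scatter of each other, so neither stands clearly apart. Compound 2 `CC1=CC[C@@H]([C@@](C)(O)CCCC(C)(C)NC(=S)NN)CC1` shows only a limit of the assay (> 100000 nM). Two steps have been measured (an at least 2.0-fold higher number from compound 1 to compound 2 (0.31 log units; beyond the scatter)) and (an at least 3.1-fold lower number from compound 2 to compound 3 (0.50 log units; beyond the scatter)), and neither of them alters a group on the aromatic ring. Compound 4 `CC1=CC[C@@H]([C@@](C)(O)CCCC(C)(C)NC(=S)N/N=C\c2ccc([N+](=O)[O-])cc2)CC1` puts nitro in place of hydroxy on an aromatic carbon, para to a large group (nitro in place of hydroxy on an aromatic carbon). Going by the values given here, with compound 3 (31500 nM) as the only direct guide, no step beyond the scatter is expected (a 1.1-fold lower number from compound 3 to compound 4 (0.02 log units; within the scatter)). In this assay the estimate for compound 4 is 30000 nM with an expected range (12000 nM to 80000 nM).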

Compound 4, concentration for total growth inhibition: 62800 nM
For compound 4 the middle estimate is 2.1-fold (0.32 log units) below the measured one; the range from low to high includes it.
By their numbers in this assay, from the lowest: compounds 3, 1 and 4 (each within the scatter of the next). At a limit, above all of these: compound 2.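

In this assay, nitro in place of hydroxy on this aromatic carbon gives a 2.0-fold higher number from compound 3 to compound 4 (0.30 log units; within the scatter), so the swap makes no change beyond the scatter at this position. The hydroxy's hydrogen-bond donor is therefore not shown to be needed here, as nitro has none and compound 4 still cannot be told apart from compound 3. Nothing measured here bears on why the two compounds compare this way.

From the compounds shown here alone, whether an amine or a carboxylic acid on this same carbon would stand clearly apart from compound 3 remains open. So does the effect of a methoxy group there.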